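The source may hold more compounds than are shown below. What is called first, only, known or untested is meant among the compounds shown, and "the series" means these compounds.

Measured compounds:
- compound 1 `C=CCCC/C=C/C=C\CCCCCCCC[C@@H]1CC[C@@H]([C@@H]2CC[C@@H](CC(=O)O)OO2)O1` gives 0.1 ug/mL in a functional assay on DU-145 cells (Homo sapiens) for cytotoxicity; a lower number here means a stronger inhibitor, a higher number a weaker inhibitor
- compound 2 `C=CCCC/C=C/C=C\CCCCCCCC[C@H]1CC[C@H]([C@@H]2CC[C@@H](CC(=O)OC)OO2)O1` gives 0.1 ug/mL in this assay
- compound 3 `C=CCC/C=C\C=C/CCCCCCCC[C@@H]1CC[C@@H]([C@@H]2CC[C@@H](CC(=O)O)OO2)O1` gives 0.1 ug/mL in this assay

All three compounds share a cyclic peroxide core carrying a long unsaturated chain. Compound 2 sits level with compound 1 and compound 3 at the digits given; how the core of compound 2 differs from that of compound 1 is not broken down here. Compound 1 and compound 3 differ by a group of 6 heavy atoms (6 carbon; no ring) in place of a group of 7 heavy atoms (7 carbon; no ring), on a double-bonded chain carbon bound to a double-bonded chain carbon, and that step gave no change at the digits printed from compound 1 to compound 3 (within the scatter). Compound 4 `C=CCC/C=C\C=C/CCCCCCCC[C@H]1CC[C@H]([C@@H]2CC[C@@H](CC(=O)OC)OO2)O1` is the unmeasured partner: it arises from compound 2 by a group of 6 heavy atoms (6 carbon; no ring) in place of a group of 7 heavy atoms (7 carbon; no ring), on a double-bonded chain carbon bound to a double-bonded chain carbon, the same change at the same place. Because that change gave no change at the digits printed from compound 1 to compound 3 (within the scatter) on compound 1, the step from compound 2 to compound 4 is expected to be similarly flat, no change at the digits printed from compound 2 to compound 4 (within the scatter). Compound 4 is therefore estimated at 0.1 ug/mL in this assay, with a plausible range from 0.05 ug/mL to 0.2 ug/mL.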

Compound 4, half-maximal inhibitory concentration: 0.1 ug/mL
Estimate against measurement, compound 4: no gap at the digits printed; low and high end bracket the measured number.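

In this assay, putting the group of 6 carbons in place of hepta-1,6-dien-1-yl gives no change at the digits printed from compound 2 to compound 4 (within the scatter), and the step matches the one seen on the other core: the same change on two cores in this assay, no change at the digits printed (within the scatter) from compound 1 to compound 3 and no change at the digits printed (within the scatter) from compound 2 to compound 4, 1.0-fold (0.00 log units) apart, within the scatter of two such steps. For these two cores, then, this change carries over from one to the other with no visible effect on the read-out. Among these compounds, it does not show that the chain end is unimportant in general, since only this one flat change is seen and a flat step says little about how a change that does shift the value would carry over.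

As far as these compounds go, whether a saturated chain, a much shorter chain or an amide in place of the carboxylic acid would hold this level stays open. So does the effect of any such group on cells other than these.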